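A few compounds are considered here, and "the series" means these few. Any claim that something is new, unique, unknown or untested is made for them only; others in the source may bear on it.

Measured so far in a functional assay on HeLa cells (Homo sapiens) for cytotoxicity, read by MTT assay, with a stated time of 72 h; a lower number here means a stronger inhibitor, a higher number a weaker inhibitor:
compound 1 `Cc1ccc(C(=O)Nc2nnc(-c3ccc(O)c(O)c3)s2)cc1` gives 67100 nM
compound 2 `O=C(Nc1nnc(-c2ccc(O)c(O)c2)s1)C1CCCCC1` gives 34500 nM
compound 3 `Cc1ccc(C(=O)Nc2nnc(-c3cccc(O)c3O)s2)cc1` gives 13400 nM

Compound 1 and compound 2 share one core and differ by cyclohexyl in place of 4-methylphenyl on a carbonyl carbon. For the measured compounds named here, the step of a 1.9-fold lower number from compound 1 to compound 2 (0.29 log units; within the scatter) is the only measured instance of this change. Compound 3 is built from the same atoms as compound 1 joined differently, and the difference between the two cores is not broken down here. Compound 4 `O=C(Nc1nnc(-c2cccc(O)c2O)s1)C1CCCCC1` is not yet measured; it differs from compound 3 by cyclohexyl in place of 4-methylphenyl on a carbonyl carbon, the same change made at the same place as in the earlier pair. The step to compound 4 is expected to be a 1.5-fold lower number from compound 3 to compound 4 (0.17 log units; within the scatter) because the earlier step of this kind a 1.9-fold lower number from compound 1 to compound 2 (0.29 log units; within the scatter) lay within the scatter. In this assay compound 4 is expected to give 9000 nM, estimated to lie between 4000 nM and 25000 nM.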

Compound 4, half-maximal inhibitory concentration: 91600 nM
Beside the measured number, compound 4's estimate is 10-fold (1.01 log units) below it; the measured number lies above the stated range.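

In this assay, cyclohexyl in place of 4-methylphenyl on a carbonyl carbon gives a 6.8-fold higher number from compound 3 to compound 4 (0.83 log units; beyond the scatter), so the change does not carry over unchanged from one core to the other: the same change on two cores in this assay, a 1.9-fold lower number (0.29 log units; within the scatter) from compound 1 to compound 2 and a 6.8-fold higher number (0.83 log units; beyond the scatter) from compound 3 to compound 4, 13-fold (1.12 log units) apart, beyond the scatter of two such steps

A step read on one of these two cores is therefore no safe guide to the same change on the other. For the compounds shown here, with only one step per core, this does not show which difference between the cores matters, nor how the change would behave on any further core.

The compounds shown leave open whether a longer alkyl chain, a benzyl group or an amine on the carbonyl carbon would also give different steps on the two cores. As far as these compounds go, whether methoxy in place of either hydroxyl would alter that gap also remains open.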